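The source may hold more compounds than are shown below. What is called first, only, known or untested is meant among the compounds shown, and "the series" means these compounds.

Measured so far:
- compound 1 `Cc1nn(-c2ncnc3nc[nH]c23)c2c1C(C(=O)N(C)c1nccs1)CC(=O)N2` — 3300 nM
- compound 2 `Cc1nn(-c2ncnc3nc[nH]c23)c2c1C(OCc1ccc(F)cc1)CC(=O)N2` — 126 nM
- compound 3 `Cc1nn(-c2ncnc3nc[nH]c23)c2c1C(c1ccc(F)cc1Cl)CC(=O)N2` — 280 nM

All three share one core and differ only at the saturated ring carbon. In a functional assay on HEK293 cells for agonist activity at G-protein coupled receptor 39 (Homo sapiens), read by scintillation proximity assay and inositol phosphate accumulation, with a stated time of 75 min (on this read-out lower numbers stand for an effect already at smaller amounts and higher numbers for an effect only at larger amounts of compound), compound 3 gives 280 nM, the second highest of the three numbers; its nearest neighbour is compound 2 (a 2.2-fold higher number from compound 2 to compound 3 (0.35 log units; beyond the scatter)), the furthest is compound 1 (a 12-fold lower number from compound 1 to compound 3 (1.07 log units; beyond the scatter)). The step to compound 4 `Cc1nn(-c2ncnc3nc[nH]c23)c2c1C(OCC(C)C)CC(=O)N2` is isobutoxy in place of 2-chloro-4-fluorophenyl on a saturated ring carbon.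

For the measured compounds named here, two measured steps bear on this. a 12-fold lower number from compound 1 to compound 3 (1.07 log units; beyond the scatter) and a 26-fold lower number from compound 1 to compound 2 (1.42 log units; beyond the scatter) show that the group on this carbon moves the number over a wide span. a 2.2-fold higher number from compound 2 to compound 3 (0.35 log units; beyond the scatter) shows that an ether-linked group here gave a modestly lower number than the aryl group, but that ether carried a ring, which isobutoxy does not. Going by the values given here, no measured compound has a chain without a ring at this position, so the direction is open. For compound 4 a modest step toward a higher number in this assay is expected, a 2.1-fold higher number from compound 3 to compound 4 (0.33 log units; beyond the scatter), with a wide range. The estimate for compound 4 is 600 nM, between 150 nM and 3000 nM.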

Compound 4, half-maximal effective concentration: 111 nM
Compound 4: the middle estimate sits 5.4-fold (0.73 log units) above what was measured; measured number outside the range, below it.
By their numbers in this assay, from the lowest: compounds 4 and 2 (each within the scatter of the next); then compound 3; then compound 1.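

In this assay, a ring on the ether is not required at this saturated ring carbon: a 1.1-fold lower number from compound 2 to compound 4 (0.06 log units; within the scatter), so isobutoxy and (4-fluorobenzyl)oxy cannot be told apart here. With a 2.5-fold lower number from compound 3 to compound 4 (0.40 log units; beyond the scatter), both ethers now stand on the lower side of the 2-chloro-4-fluorophenyl group, which compound 2 alone could not show for an ether without a ring; a 30-fold lower number from compound 1 to compound 4 (1.47 log units; beyond the scatter) adds a third large step away from methyl(1,3-thiazol-2-yl)carbamoyl. No supporting data explain these differences.

Going by these compounds, whether the oxygen itself counts stays open, and isobutyl on this carbon would test it. Also open, on these data alone, is how a longer chain, or an amine or a carboxylic acid at the end of the ether chain, would move the number.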